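This account rests on a few compounds, and the source may have more. Where it says the series, first, only, none or still open, it means among the compounds named here.

Working notes on the series. Among the measured compounds shown here, compound 1 `CNc1nc(NC2(C#N)CCCCC2)nc(-n2ccnc2)n1` is the only member with a numeric result in an in vitro assay on Sf21 cells for inhibition of high affinity 3',5'-cyclic-AMP phosphodiesterase 7A (Homo sapiens) (on this read-out higher numbers stand for weaker inhibition and lower numbers for stronger inhibition), where compound 1 gives 1050 nM. Compound 2 `CNc1nc(NC2(C#N)CCCCC2)nc(-n2cnc3ccccc32)n1` is recorded in this assay only as a limit, and compound 2 sits at > 1000 nM, which is the limit described by the limit of > 1000 nM in this assay, at which 1 of the 2 values shown sits, and not a measured number. With one number and one limit, compound 1 stands as the sole fixed point of the series in this assay.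

Compound 3 `CNc1nc(Nc2ccccc2)nc(NC2(C#N)CCCCC2)n1` has not been measured in this assay. It differs from compound 1 by anilino in place of 1H-imidazol-1-yl on an aromatic carbon, in words anilino in place of 1H-imidazol-1-yl on an aromatic carbon. For the measured compounds named here, no step between measured compounds bears on this exchange, so the expectation rests on compound 1 alone, and no direction can be read from the two values shown. The expected step from compound 1 to compound 3 in this assay is a 1.3-fold lower number from compound 1 to compound 3 (0.12 log units; within the scatter), that is a small movement that may well fall within the scatter. For compound 3 the estimated value in this assay is 800 nM, with a range from 200 nM to 4000 nM.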

Compound 3, half-maximal inhibitory concentration: > 5000 nM
Compound 3: no number, only a limit; the forecaster's own chance of this, stated with the estimate: 30%; middle value at least 6.2-fold (0.79 log units) from the limit.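

In this assay, the position between two ring nitrogen atoms and opposite the ring nitrogen now has a step that can be read: anilino in place of 1H-imidazol-1-yl gives an at least 4.7-fold higher number from compound 1 to compound 3 (0.67 log units; beyond the scatter). On these data alone, the result for compound 3 is a limit and not a number: the limit of > 5000 nM in this assay, at which 1 of the 3 values shown sits. So this position does not take every aromatic group alike: the exchange brings in a six-membered aromatic ring of carbon only with a hydrogen-bond donor, and the read-out moves towards weaker inhibition by an amount beyond the scatter, though its full size stays unknown.

Steps involving compound 2 cannot be read, as its result is also a limit and not a number: the limit of > 1000 nM in this assay, at which 1 of the 3 values shown sits. Still open is whether the change in the number goes with the loss of the five-membered aromatic ring with 2 hetero atoms or with the hydrogen-bond donor that enters, and whether a morpholino group or a methoxy group on the same carbon would stay close to compound 1.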